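The source may hold more compounds than are shown below. What is called first, only, known or untested is meant among the compounds shown, and "the series" means these compounds.

Working notes on the series. Compound 1 `CCOC(=O)C(C)C(O)(c1ccc(OC)c(OC)c1OC)c1cccc2ccccc12` sits at a limit of a functional assay on HCT-116 cells (Homo sapiens) for inhibition, read by sulforhodamine B assay, with a stated time of 48 h; on this read-out higher numbers stand for weaker inhibition and lower numbers for stronger inhibition: in this assay compound 1 gives > 20000 nM, a limit and not a number. Compound 2 `COc1ccc(C(O)(C/C=C\c2ccccc2)c2cccc3ccccc23)c(OC)c1OC` likewise reaches only a limit: in this assay compound 2 gives > 20000 nM. Going by the values given here, compound 3 `COc1ccc(/C(=N/O)c2cccc3ccccc23)c(OC)c1OC`, the one compound of the three with a number, gives 5880 nM in this assay. Compound 2 therefore stands at the limit of > 20000 nM in this assay, at which 2 of the 3 values shown sit, with no number of its own. Among the compounds with values here, the one step measured on this series, a step that the two limits leave unreadable from compound 1 to compound 2, is of unreadable size, so nothing measured bears on the change to compound 4 `COc1ccc(C(O)(Cc2ccccc2)c2cccc3ccccc23)c(OC)c1OC` beyond the position of compound 2 at the limit. The change is phenyl in place of 2-phenylethenyl on a saturated chain carbon, two bonds along the chain from two aromatic carbons and an oxygen on a saturated carbon. Within the data shown here, no measured step tells its direction, and the step that the limit leaves unreadable from compound 2 to compound 4 is expected to stay within the scatter, with the limit again the most likely report. Compound 4 is estimated at 35000 nM in this assay, between 12000 nM and 100000 nM.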

Compound 4, half-maximal inhibitory concentration: > 20000 nM
Compound 4: only a limit was reported (the forecaster's own chance of this, stated with the estimate: 75%); the middle value is on the limit's open side.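

In this assay compound 4 gives > 20000 nM, a limit and not a number, so the steps to compound 4 from compound 1 and compound 2 cannot be read. The compounds shown leave open how compound 1, compound 2 and compound 4 rank, as none has a number of its own.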